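The compounds below may be only part of what the source reports. "The series", "measured", "known", "first", "only" and "open" are said of these compounds alone.

Measured compounds:
compound 1 `Nc1nc(Cl)c(-c2ccccn2)c(N[C@@H]2C[C@H](CO)[C@@H](O)[C@H]2O)n1`: > 25000 nM
compound 2 `Nc1nc(Cl)c(-c2nc3ccc(Cl)cc3s2)c(N[C@@H]2C[C@H](CO)[C@@H](O)[C@H]2O)n1`: 16000 nM
compound 3 `CNc1nc(C)c(-c2nc3ccccc3s2)c(N[C@@H]2C[C@H](CO)[C@@H](O)[C@H]2O)n1`: > 25000 nM

In an ADME assay on cells (Homo sapiens) for cytotoxicity, read by polymerase chain reaction, with a stated time of 3 days (on this read-out lower numbers stand for higher toxicity in this test and higher numbers for lower toxicity in this test), compound 1 reports only a limit of the assay, > 25000 nM. Going by the values given here, compound 2 is the one compound with a measured number in this assay, 16000 nM. Compound 3 again reaches only a limit, > 25000 nM. Among the compounds with values here, no two of the measured compounds differ in a single place, so no measured step is available; where compound 3 stands is simply (the limit of > 25000 nM in this assay, at which 2 of the 3 values shown sit), and nothing more can be read from its value against compound 1 or compound 2.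

Compound 4 `Cc1nc(NCc2ccccc2)nc(N[C@@H]2C[C@H](CO)[C@@H](O)[C@H]2O)c1-c1nc2ccccc2s1` differs from compound 3 by phenyl in place of hydrogen on a saturated chain carbon bound to a nitrogen on an aromatic ring. Since compound 3 sits at a limit, the direction of the change cannot be checked against the shown numbers; the account expects at most a modest shift toward higher toxicity, an at least 1.3-fold lower number from compound 3 to compound 4 (0.14 log units; that floor lies within the scatter), which may well stay within the scatter. Compound 4 is therefore estimated at 18000 nM in this assay, within 5000 nM to 40000 nM, with a fair chance that only a limit is reported again.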

Compound 4, half-maximal cytotoxic concentration: 9000 nM
The estimate for compound 4 lay 2.0-fold (0.30 log units) above the measured number, within the range that was stated.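

In this assay, going by these compounds alone, this position now gives a reading: phenyl in place of hydrogen on a saturated chain carbon bound to a nitrogen on an aromatic ring brings an at least 2.7-fold lower number from compound 3 to compound 4 (0.44 log units; beyond the scatter), a move toward higher toxicity in this test and the only single-place step in the set. Compound 3 gives > 25000 nM, which is a limit. The step therefore has a floor but no known upper end because of where compound 3 sits: the limit of > 25000 nM in this assay, at which 2 of the 4 values shown sit.

The compounds shown hold only methylamino and benzylamino at this place, so it stays open whether the aromatic ring itself matters or any larger group would do; a cyclohexylmethylamino group or a plain propylamino chain would tell these apart. Going by these compounds, it also stays open whether the same change gives a similar step on the core of compound 1 or compound 2.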